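The compounds below may be only part of what the source reports. "The series", "measured", "known", "first", "only" and "open" are said of these compounds alone.

Measured compounds:
Compound 1, `Cc1ccccc1Nc1nc(C)c(C(=O)/C=C/c2ccccc2)s1`: > 25000 nM
Compound 2, `COc1cccc(/C=C/C(=O)c2sc(Nc3ccccc3C)nc2C)c1`: > 25000 nM

In a functional assay on Bel-7402 cells (Homo sapiens) for cytotoxicity, read by MTT assay (on this read-out higher numbers stand for weaker inhibition and lower numbers for stronger inhibition), compound 1 gives > 25000 nM, which is a limit of the assay rather than a number. Compound 2, which carries a methoxy in place of a hydrogen on an aromatic carbon of the styryl ring, gives > 25000 nM in this assay, again a limit of the assay and not a number. Among the measured compounds shown here, the step that the two limits leave unreadable from compound 1 to compound 2 is therefore unreadable, since both ends sit at the same limit; this is the only measured step available, and it is summed up by the limit of > 25000 nM in this assay, at which 2 of the 2 values shown sit.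

Compound 3 is `Cc1ccc(Nc2nc(C)c(C(=O)/C=C/c3ccccc3)s2)cc1`. It differs from compound 1 in that (4-methylphenyl in place of 2-methylphenyl on a nitrogen on an aromatic ring). For the measured compounds named here, no measured step bears on this change, because the single measured step that the two limits leave unreadable from compound 1 to compound 2 concerns a different position and is unreadable. Going by the values given here, the only guidance is that both measured compounds sit at the limit, so compound 3 is expected most likely to do the same, and the step that the limit leaves unreadable from compound 1 to compound 3 is expected to stay within the scatter. Compound 3 is accordingly estimated at 30000 nM, with a range from 10000 nM to 100000 nM.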

Compound 3, half-maximal inhibitory concentration: > 25000 nM
Compound 3 ended at the assay's limit; the forecaster's own chance of this, stated with the estimate: 80%; the middle value does not contradict the limit.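

In this assay compound 3 gives > 25000 nM as a limit of the assay and not a number. Among the compounds shown here, compound 1 also sits at a limit, so no step from compound 1 to compound 3 can be read, and the result adds only this: the limit of > 25000 nM in this assay, at which 3 of the 3 values shown sit. The compounds shown leave open whether any change on the shared core would give a readable value in this assay.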